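The source may report more compounds than this note shows. Statements on the series, on what has been measured and on what is new or still open speak of the compounds shown alone.

Compound 1, `O=C1C(=O)N(CN2CCN(c3ccnc4cc(C(F)(F)F)ccc34)CC2)c2cccc(Cl)c21`: 16900 nM
Compound 2, `O=C1C(=O)N(CN2CCN(c3ccnc4cc(C(F)(F)F)ccc34)CC2)c2cccc(Br)c21`: 66800 nM
Compound 3, `NC(=S)N/N=C1/C(=O)N(CN2CCN(c3ccnc4cc(C(F)(F)F)ccc34)CC2)c2cccc(Cl)c21`: 21600 nM

Of the compounds shown here, three have been measured in a functional assay on MCF7 cells (Homo sapiens) for cytotoxicity, read by sulforhodamine B assay, with a stated time of 48 h; on this read-out lower numbers stand for stronger inhibition of growth and higher numbers for weaker inhibition of growth. Compound 1 gives 16900 nM, and compound 2, which differs from it by bromo in place of chloro on an aromatic carbon, gives 66800 nM; the step between them is a 4.0-fold higher number from compound 1 to compound 2 (0.60 log units; beyond the scatter). Compound 3 gives 21600 nM in this assay, a value within the scatter of that of compound 1, so the two cannot be ordered. The difference between the core of compound 3 and the core of compound 1 is not broken down here.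

Compound 4, `NC(=S)N/N=C1/C(=O)N(CN2CCN(c3ccnc4cc(C(F)(F)F)ccc34)CC2)c2cccc(Br)c21`, has not yet been measured in this assay. It differs from compound 3 by bromo in place of chloro on an aromatic carbon, the same change made from compound 1 to compound 2. Within the data shown here, only that one measured example of the change is available, and it rests on a single pair, so the weight it can carry is limited. Among the measured compounds shown here, still, the one measured step is a 4.0-fold higher number from compound 1 to compound 2 (0.60 log units; beyond the scatter), and the expectation is that the change from compound 3 to compound 4 goes in the same direction, since compound 3 starts from a value close to that of compound 1. Compound 4 is therefore expected to give about 60000 nM in this assay, with a plausible range from 25000 nM to 150000 nM, which corresponds to an expected step of a 2.8-fold higher number from compound 3 to compound 4 (0.44 log units; beyond the scatter).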

Compound 4, concentration for 50% growth inhibition: 50600 nM
Beside the measured number, compound 4's estimate is 1.2-fold (0.07 log units) above it, within the range that was stated.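

Bromo in place of chloro on an aromatic carbon again goes with weaker inhibition of growth in this assay, with a 2.3-fold higher number from compound 3 to compound 4 (0.37 log units; beyond the scatter). Set beside the earlier step, the change carries over from one core to the other in direction, and the sizes of the two steps cannot be told apart: the same change on two cores in this assay, a 4.0-fold higher number (0.60 log units; beyond the scatter) from compound 1 to compound 2 and a 2.3-fold higher number (0.37 log units; beyond the scatter) from compound 3 to compound 4, 1.7-fold (0.23 log units) apart, within the scatter of two such steps This agreement rests on only two matched pairs, both with the same exchange at the same place, so it does not show that the change would behave alike on any other core in the series, and it gives no explanation for the step.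

The compounds shown leave open what a fluoro, iodo, methyl or methoxy group would do at this same place on the ring, and so whether the two halogens seen here are part of any wider trend. They also leave open whether the step from chloro to bromo would persist if the trifluoromethyl group were replaced by a nitrile or a methoxy group, or if the same pairs were compared in cells other than those of this single assay.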